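Replacing a Large Substituent with Amino on the Shared Core

The source may hold more compounds than are shown below. What is called first, only, known or untested is meant among the compounds shown, and "the series" means these compounds.

Three compounds have been measured in a functional assay on the whole organism (strain albino) for inhibition, with Rattus norvegicus as the target, read by paw edema, with stated times of 1 h and 2 h, at a dose of 20 mmol/kg by the intraperitoneal route; a higher number here means more inhibition at the dose given (going by the name of the read-out), a lower number less inhibition:

compound 1, `N#CC1=C(NCC(=O)N2CCOCC2)N(c2ccccc2)C(=O)N2CCCCC(N3CCCC3)C12`: 69.8%
compound 2, `N#CC1=C(/N=C/Nc2ccc([N+](=O)[O-])cc2)N(c2ccccc2)C(=O)N2CCCCC(N3CCCC3)C12`: 41.5%
compound 3, `N#CC1=C(/N=C/Nc2ccccc2)N(c2ccccc2)C(=O)N2CCCCC(N3CCCC3)C12`: 47.5%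

Compound 2 gives the lowest of the three numbers in this assay; compound 3 lies close to it, a number 6 percentage points higher from compound 2 to compound 3 (within the scatter), whereas compound 1 stands well above, a number 28.3 percentage points lower from compound 1 to compound 2 (beyond the scatter).

Compound 4, `N#CC1=C(N)N(c2ccccc2)C(=O)N2CCCCC(N3CCCC3)C12`, has not yet been measured in this assay. It differs from compound 2 at one point: one nitrogen atom in place of a group of 12 heavy atoms (7 carbon, 3 nitrogen, 2 oxygen; one six-membered aromatic ring of carbon only), on a double-bonded ring carbon.

Going by the values given here, the steps that bear on this position are a number 28.3 percentage points lower from compound 1 to compound 2 (beyond the scatter) and a number 22.3 percentage points lower from compound 1 to compound 3 (beyond the scatter). Both show that exchanging the group on this double-bonded ring carbon moves the read-out by a modest but real amount, and that the two aromatic groups in compound 2 and compound 3 sit below the larger non-aromatic group in compound 1. Among the compounds with values here, no measured compound carries a plain amino at this place, so the direction for compound 4 is not fixed by a direct analogue. Given that compound 1 shows the change at this position can raise the number, as in a number 28.3 percentage points lower from compound 1 to compound 2 (beyond the scatter), a rise of some size from compound 2 to compound 4 is expected, a number 13.5 percentage points higher from compound 2 to compound 4 (beyond the scatter), though with wide uncertainty. Compound 4 is therefore estimated at 55%, in the range 38% to 72%.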

Compound 4, a percentage reported as inhibition, in the whole organism at one dose (the size of the read-out at that dose, not a potency): 86.9%
Compound 4: middle estimate off by 31.9 percentage points, on the low side; the measured number lies above the stated range.
By their numbers in this assay, from the lowest: compounds 2 and 3 (each within the scatter of the next); then compound 1; then compound 4.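

In this assay, the plain amino group on the double-bonded ring carbon stands well above both groups carrying an aromatic ring, with large steps (a number 45.4 percentage points higher from compound 2 to compound 4 (beyond the scatter)) and (a number 39.4 percentage points higher from compound 3 to compound 4 (beyond the scatter)). It also stands above the ((morpholin-4-yl)carbonyl)methyl on the amine nitrogen, a modest step (a number 17.1 percentage points higher from compound 1 to compound 4 (beyond the scatter)), so compound 1 no longer marks the top of what this place allows. Among these four compounds, the smallest group gives the highest number, and removing the ((morpholin-4-yl)carbonyl)methyl raises the number rather than lowering it.

As far as these compounds go, whether a methyl or an acetyl on this amino nitrogen would keep the number at the level of compound 4 remains open. Nothing available gives a reason for these steps.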